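The compounds below may be only part of what the source reports. "The series", "measured", "known", "first", "only" and "open" are said of these compounds alone.

Measured compounds:
- compound 1, `COc1ccc(/C=N/Nc2nc3ccccc3nc2Cc2ccccc2)cc1OC`, in an assay on isolated protein for inhibition of Amine oxidase [flavin-containing] B (Homo sapiens), read by spectrophotometry (a higher number here means a weaker inhibitor, a lower number a stronger inhibitor), compound 1 gives 460000 nM
- compound 2, `C(=N/Nc1nc2ccccc2nc1Cc1ccccc1)\c1ccccc1`, compound 2 gives 320000 nM
- compound 3, `C/C(=N\Nc1nc2ccccc2nc1Cc1ccccc1)c1ccc(O)cc1`, compound 3 gives 8400000 nM

Compound 2 holds the lowest of the three numbers, but its nearest neighbour, compound 1, lies within the scatter of it: a 1.4-fold lower number from compound 1 to compound 2 (0.16 log units; within the scatter). Going by the values given here, compound 3 stands far away, and no single-place step connects it to compound 2; its number and that of compound 2 only show that a hydroxy-bearing ring together with a methyl on the carbon with the double bond to nitrogen sits much higher.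

Compound 4, `Oc1ccc(/C=N/Nc2nc3ccccc3nc2Cc2ccccc2)cc1`, is reached from compound 2 by hydroxy in place of hydrogen on an aromatic carbon. Among the compounds with values here, the only measured one-place step, the exchange of groups on the same ring from compound 1 to compound 2, was within the scatter. Nothing measured separates the hydroxy from the methyl in compound 3. On that basis no step beyond the scatter is expected, with the range widened upward because compound 3 gives 8400000 nM. The expected step is a 1.4-fold higher number from compound 2 to compound 4 (0.15 log units; within the scatter). Compound 4 is estimated at 450000 nM, between 150000 nM and 2000000 nM.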

Compound 4, half-maximal inhibitory concentration: 7900000 nM
For compound 4 the middle estimate is 18-fold (1.24 log units) below the measured one; the whole stated range lies below it.
By their numbers in this assay, from the lowest: compounds 2 and 1 (each within the scatter of the next); then compounds 4 and 3 (each within the scatter of the next).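

In this assay this ring position is not indifferent to substitution: hydroxy in place of hydrogen, para to a large group, gives a 25-fold higher number from compound 2 to compound 4 (1.39 log units; beyond the scatter) and is a large change, whereas phenyl in place of 3,4-dimethoxyphenyl gives only a 1.4-fold lower number from compound 1 to compound 2 (0.16 log units; within the scatter) and stays within the scatter. The 4-hydroxyphenyl ring also stands apart from the 3,4-dimethoxyphenyl ring, with a 17-fold higher number from compound 1 to compound 4 (1.23 log units; beyond the scatter) as a second large step, so among these compounds oxygen-bearing rings do not all read alike. Compound 4 gives 7900000 nM and compound 3 gives 8400000 nM in values within the scatter of each other, so the high number of compound 3 goes with the 4-hydroxyphenyl ring it shares with compound 4, and the methyl on the carbon with the double bond to nitrogen adds no separable change.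

No supporting data bear on why the hydroxy raises the number so sharply. Open too, going by these compounds, is whether the same rise follows a single methoxy, an amine, a carboxylic acid or a fluorine at this place on the ring.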